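A few compounds are considered here, and "the series" means these few. Any claim that something is new, unique, unknown or untested is made for them only; others in the source may bear on it.

The pair of measured compounds share one core and a small range of results. Compound 1 `COc1cccc2c1c(C(=O)/C=C(\O)C(=O)O)cn2Cc1c(F)cccc1F` in an ADME assay on MT4 cells (Homo sapiens) for cytotoxicity, read by MTT assay (a higher number here means that more compound is tolerated, a lower number that less compound is tolerated), gives 44300 nM. Compound 2 `CCOC(=O)/C(O)=C/C(=O)c1cn(Cc2ccccc2F)c2cccc(OC)c12` in this assay gives 63300 nM. Among these two numbers compound 1 holds the lower one, yet the gap to compound 2 lies within the scatter of repeated measurements, so the two values read as the same tolerance rather than as an order.

The unmeasured compound 3 `COc1cccc2c1c(C(=O)/C=C(\O)C(=O)O)cn2Cc1cccc(F)c1F` differs from compound 1 only in the benzyl group on the aromatic nitrogen. The change, (2,3-difluorophenyl in place of 2,6-difluorophenyl on a saturated chain carbon bound to an aromatic nitrogen), keeps every atom and shifts only the placing of the two fluorines on the ring. Going by the values given here, no measured pair in this set isolates such a rearrangement, so nothing here shows how this assay responds to it.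

With the same atoms joined differently and no evidence of sensitivity, compound 3 is expected to stay close to compound 1, the expected step of a 1.0-fold higher number from compound 1 to compound 3 (0.01 log units; within the scatter) being none beyond the scatter. Compound 3 is therefore estimated at 45000 nM in this assay, with a range of 20000 nM to 100000 nM.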

Compound 3, half-maximal cytotoxic concentration: 17500 nM
Beside the measured number, compound 3's estimate is 2.6-fold (0.41 log units) above it, and the stated range ends above it.
By their numbers in this assay, from the lowest: compound 3; then compounds 1 and 2 (each within the scatter of the next).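

Shifting the two fluorines from 2,6-difluorobenzyl to 2,3-difluorobenzyl is the first change in one place that can be read in this assay, and it gives a 2.5-fold lower number from compound 1 to compound 3 (0.40 log units; beyond the scatter) even though the atoms stay the same. Going by these compounds alone, this shows that, on a saturated chain carbon bound to an aromatic nitrogen, the placing of the fluorines alone can alter how much compound is tolerated, something the earlier compounds, which differ in more than one place, could not show. Nothing available explains why this rearrangement has this effect, so the step stands only as an observation.

The compounds shown leave open whether the same shift would have a similar effect on the ethyl ester of compound 2, which carries a single fluorine on its benzyl group and so offers no direct counterpart. They also leave open how the tolerated concentration would respond if a chlorine atom or a nitrile took the place of one of the fluorines on this ring.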